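A few compounds are considered here, and "the series" means these few. Any claim that something is new, unique, unknown or untested is made for them only; others in the source may bear on it.

Going by the values given here, compound 1 `ClCc1ccccc1Cn1cnc2ncnc(Cl)c21` is the only member of this pair to give a number in a functional assay on K562 cells (Homo sapiens) for cytotoxicity, read by sulforhodamine B assay, with a stated time of 48 h (on this read-out lower numbers stand for higher toxicity in this test and higher numbers for lower toxicity in this test), where compound 1 gives 83200 nM. Compound 2 `Nc1nc(Cl)c2ncn(Cc3cccc(CCl)c3)c2n1` reaches only a limit of the assay in this assay, where compound 2 gives > 100000 nM. Compound 1 therefore stands alone as the finite value beside (the limit of > 100000 nM in this assay, at which 1 of the 2 values shown sits). Among the compounds with values here, compound 3 `ClCc1ccccc1Cn1cnc2nc(Cl)nc(Cl)c21` differs from compound 1 by chloro in place of hydrogen on an aromatic carbon, and no measured step of this kind exists here. In this assay the expected step is a 1.7-fold lower number from compound 1 to compound 3 (0.22 log units; within the scatter), small and toward higher toxicity if anything. Compound 3 is accordingly estimated at 50000 nM, in a range from 15000 nM to 120000 nM.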

Compound 3, concentration lethal to 50% of the cells: > 100000 nM
Compound 3: only a limit was reported (the forecaster's own chance of this, stated with the estimate: 25%); at least 2.0-fold (0.30 log units) between middle value and limit.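

In this assay, chloro in place of hydrogen on the aromatic carbon between two ring nitrogen atoms gives an at least 1.2-fold higher number from compound 1 to compound 3 (0.07 log units; that floor lies within the scatter). Compound 3 gives > 100000 nM, which is a limit of the assay and not a number. The step therefore has only a floor, and this change shows no gain in toxicity in this test, with most of the values now resting on the same limit: the limit of > 100000 nM in this assay, at which 2 of the 3 values shown sit.

On these data alone, how far the chloro change really moves the number stays open. So does whether a methyl or a methoxy group at this position would give a finite value.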